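Chloro for Ethyl on a Cell-Growth Inhibitor

The compounds below may be only part of what the source reports. "The series", "measured", "known", "first", "only" and "open" are said of these compounds alone.

Compound 1 `C=C(Br)C(=O)Nc1cccc(-c2cn3nc(-c4ccc(CC)cc4)sc3n2)c1`: 3200 nM
Compound 2 `COc1ccc(Cc2nn3cc(-c4cccc(N)c4)nc3s2)cc1`: 191000 nM
Compound 3 `COc1ccc(-c2csc3nc(-c4cccc(N)c4)cn23)cc1`: 19000 nM

All three compounds were tested in a functional assay on HeLa cells (Homo sapiens) for inhibition, read by cell counting, with a stated time of 4 days; a higher number here means a weaker inhibitor, a lower number a stronger inhibitor. Compound 1 gives the lowest number of the three, so it is the strongest inhibitor of this small set. Its nearest neighbour is compound 3, whose number is higher by more than the usual scatter. Compound 2 gives the highest number of all, again well beyond the scatter. Compound 2 and compound 3 each differ from compound 1 in more than one place, so no single structural change can be tied to these gaps; the values simply show that compound 1 stands clearly ahead.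

Compound 4 `C=C(Br)C(=O)Nc1cccc(-c2cn3nc(-c4ccc(Cl)cc4)sc3n2)c1` has not yet been measured in this assay. It differs from compound 1 in one place only: chloro in place of ethyl on an aromatic carbon. Among the compounds with values here, no pair of measured compounds here shows what such a swap does to the cell-growth read-out, so there is no measured step to lean on. The exchange keeps the rest of compound 1 untouched, and a change of this kind is expected to move the number little. The step from compound 1 to compound 4 is estimated as a 1.1-fold higher number from compound 1 to compound 4 (0.04 log units; within the scatter), within the scatter. Compound 4 is therefore expected to give about 3500 nM, most likely between 1200 nM and 10000 nM.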

Compound 4, half-maximal inhibitory concentration: 3000 nM
Compound 4: the middle estimate sits 1.2-fold (0.07 log units) above what was measured; low and high end bracket the measured number.
By their numbers in this assay, from the lowest: compounds 4 and 1 (each within the scatter of the next); then compound 3; then compound 2.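

In this assay, within the data shown here, chloro in place of ethyl gives a 1.1-fold lower number from compound 1 to compound 4 (0.03 log units; within the scatter) and this is the first comparison in the set where only one place changes. The step stays within the usual scatter of repeated measurements, so compound 1 and compound 4 cannot be told apart, and 4-ethylphenyl and 4-chlorophenyl serve equally well in this read-out, at this position on the aromatic ring, para to a large group, even though one heavy atom replaces two. Nothing available here explains why the number holds steady, so the result stands as an observation only.

The compounds shown leave open how far this tolerance reaches, since an amine, a carboxylic acid or a longer chain such as butyl at the same position could behave quite differently from ethyl and chloro. They also leave open whether the same exchange would give a similar step on another core, such as that of compound 3, which differs from compound 1 in more than one place.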